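Swapping Nitrophenyl for Benzyl on the Triazole Ring

The compounds below may be only part of what the source reports. "The series", "measured", "known", "first", "only" and "open" are said of these compounds alone.

This small series shares one core and varies the group hung from its amide. Compound 1 `CC(C)n1ncc2c(C(=O)Nc3ccccc3)cccc21` carries a phenyl on the amide nitrogen, and in a functional assay on PC-3 cells (Homo sapiens) for inhibition, read by MTT assay, with a stated time of 72 h (on this read-out higher numbers stand for weaker inhibition and lower numbers for stronger inhibition), compound 1 gives 11900 nM. Compound 2 `CC(C)n1ncc2c(C(=O)Nc3cccnc3)cccc21` carries a pyridin-3-yl instead. In this assay compound 2 reaches only a limit, > 40000 nM, which is not a number. That change amounts to an at least 3.3-fold higher number from compound 1 to compound 2 (0.52 log units; beyond the scatter). Compound 3 `CC(C)n1ncc2c(C(=O)NCc3cn(-c4ccc([N+](=O)[O-])cc4)nn3)cccc21` extends the amide through a triazole to a 4-nitrophenyl. In this assay, on these data alone, compound 3 likewise stands at a limit, > 40000 nM, so its real potency is unknown. Two of the three results rest at the limit of > 40000 nM in this assay, at which 2 of the 3 values shown sit. Compound 4 `CC(C)n1ncc2c(C(=O)NCc3cn(Cc4ccccc4)nn3)cccc21` differs from compound 3 by benzyl in place of 4-nitrophenyl on an aromatic nitrogen. Among the measured compounds shown here, no measured step concerns this position; the one measured step sits on the amide nitrogen, so it only shows that changing the group there can move this assay by a modest amount. Compound 4 is therefore expected to remain weak, with an estimate of 40000 nM and a range from 12000 nM to 120000 nM, which means an expected a number no higher from compound 3 to compound 4 (the limit leaves the size open).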

Compound 4, half-maximal inhibitory concentration: 4420 nM
For compound 4 the middle estimate is 9.0-fold (0.96 log units) above the measured one, outside the stated range (below it).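

Among the compounds shown here, until now no measured step touched this position, on an aromatic nitrogen of a five-membered aromatic ring with 3 nitrogen. In this assay benzyl in place of 4-nitrophenyl gives an at least 9.0-fold lower number from compound 3 to compound 4 (0.95 log units; beyond the scatter) and so shows that the group at this position can clearly change the read-out, here towards stronger inhibition. On these data alone, compound 3 rests at a limit, which is not a number, so the full size of the step stays open: the limit of > 40000 nM in this assay, at which 2 of the 4 values shown sit.

The step cannot say which part of the change carries it, the loss of the nitro group or the carbon link that benzyl places between its ring and the nitrogen. As far as these compounds go, how a 4-nitrobenzyl group or a longer chain such as 2-phenylethyl would behave at this nitrogen also remains open.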